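A few compounds are considered here, and "the series" means these few. Any claim that something is new, unique, unknown or untested is made for them only; others in the source may bear on it.

In a functional assay on SKW3 cells (Homo sapiens) for antiproliferative activity, read by WST assay, with a stated time of 3 days (on this read-out lower numbers stand for stronger inhibition and higher numbers for weaker inhibition), compound 1 `O=c1[nH]c(=O)n([C@@H]2O[C@H](CO)[C@@H](O)[C@H]2O)c(I)c1F` gives > 50000 nM, which is a limit of the assay and not a number. Going by the values given here, compound 2 `Nc1c(F)c(=O)[nH]c(=O)n1[C@@H]1O[C@H](CO)[C@@H](O)[C@H]1O` gives 600 nM, and compound 3 `CCc1c(F)c(=O)[nH]c(=O)n1[C@@H]1O[C@H](CO)[C@@H](O)[C@H]1O` gives 1200 nM, the highest actual number so far, though a 2.0-fold higher number from compound 2 to compound 3 (0.30 log units; within the scatter). The steps away from iodo are both large: an at least 83-fold lower number from compound 1 to compound 2 (1.92 log units; beyond the scatter) and an at least 41-fold lower number from compound 1 to compound 3 (1.61 log units; beyond the scatter). Compound 4 `O=Cc1c(F)c(=O)[nH]c(=O)n1[C@@H]1O[C@H](CO)[C@@H](O)[C@H]1O` has formyl in place of ethyl on an aromatic carbon. Among the compounds with values here, no measured step tests formyl, but exchanging ethyl for amino at this place left compound 2 and compound 3 level, as a 2.0-fold higher number from compound 2 to compound 3 (0.30 log units; within the scatter) shows, while compound 1 shows that a large loss remains possible here. In this assay, the expected change is therefore modest and towards a higher number: a 2.1-fold higher number from compound 3 to compound 4 (0.32 log units; beyond the scatter). For compound 4, the estimated value is 2500 nM, with an expected range from 400 nM to 20000 nM.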

Compound 4, half-maximal inhibitory concentration: 300 nM
Beside the measured number, compound 4's estimate is 8.3-fold (0.92 log units) above it; the whole stated range lies above it.
By their numbers in this assay, from the lowest: compounds 4, 2 and 3 (each within the scatter of the next, the first and the last beyond it). At a limit, above all of these: compound 1.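

In this assay, the exchange at this aromatic carbon now gives a step beyond the scatter between two groups of equal heavy-atom count: a 4.0-fold lower number from compound 3 to compound 4 (0.60 log units; beyond the scatter). Formyl and amino remain level, with a 2.0-fold lower number from compound 2 to compound 4 (0.30 log units; within the scatter), so the two cannot be ordered. The step away from iodo, an at least 160-fold lower number from compound 1 to compound 4 (2.22 log units; beyond the scatter), starts from a limit and not a number: the limit of > 50000 nM in this assay, at which 1 of the 4 values shown sits.

As far as these compounds go, whether a carboxylic acid, a hydroxymethyl group or a longer chain at this carbon would keep such numbers stays open. The compounds shown also do not explain why formyl differs from ethyl here.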